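From methyl to benzyloxycarbonyl on the shared core

The source may report more compounds than this note shows. Statements on the series, on what has been measured and on what is new or still open speak of the compounds shown alone.

In an ADME assay on HaCaT cells (Homo sapiens) for cytotoxicity, read by MTT assay, with a stated time of 48 h (on this read-out lower numbers stand for stronger inhibition and higher numbers for weaker inhibition), compound 1 (`Clc1ccc(-c2nn(-c3ccccc3)cc2-c2nc3ccccc3[nH]2)cc1`) gives > 50000 nM as a limit of the assay. Compound 2 (`Cc1ccc2[nH]c(-c3cn(-c4ccccc4)nc3-c3ccc(Cl)cc3)nc2c1`) gives > 50000 nM as a limit too. The evidence so far is the limit of > 50000 nM in this assay, at which 2 of the 2 values shown sit, and no exact number. Compound 3 (`O=C(OCc1ccccc1)c1ccc2[nH]c(-c3cn(-c4ccccc4)nc3-c3ccc(Cl)cc3)nc2c1`) carries benzyloxycarbonyl in place of methyl on an aromatic carbon of the shared core. Within the data shown here, the only measured step is a step that the two limits leave unreadable from compound 1 to compound 2 and it offers no size to carry over, so no step beyond the scatter is expected in this assay here. The expected change is a number no higher from compound 2 to compound 3 (the limit leaves the size open) by this estimate. Compound 3 is estimated at 50000 nM with an expected range from 20000 nM to 100000 nM in this assay.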

Compound 3, half-maximal inhibitory concentration: > 50000 nM
Compound 3 was reported as a limit; the forecaster's own chance of this, stated with the estimate: 75%; the middle value sits exactly at the limit.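

Among these compounds, compound 1, compound 2 and compound 3 each give only a limit in this assay, so no step among them can be read. The compounds shown leave open where each true value lies and whether any of these changes on the shared core alters it: the limit of > 50000 nM in this assay, at which 3 of the 3 values shown sit.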